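The source may hold more compounds than are shown below. What is called first, only, known or untested is meant among the compounds shown, and "the series" means these compounds.

Working notes on the series. Compound 1 `CCN(Cc1cccs1)C(=O)COc1ccc(F)cc1` in an assay on HEK293 cells for agonist activity at transient receptor potential cation channel subfamily M member 8 (Homo sapiens), read by fluorescence and calcium flux, with a stated time of 15 min (a higher number here means that more compound is needed for the effect, a lower number that less compound is needed), gives 422 nM. Compound 2 `CCN(C(=O)COc1ccc(C)cc1)C(C)c1cccs1` carries 1-(thiophen-2-yl)ethyl on the amide-type nitrogen and a methyl-bearing phenyl ether, and in this assay compound 2 gives "not active" (no number reported), so no number stands for it and its place against compound 1 cannot be fixed. Compound 3 `CCN(Cc1ccco1)C(=O)COc1ccc(C)cc1` is the next point: (furan-2-yl)methyl in place of 1-(thiophen-2-yl)ethyl on an amide-type nitrogen. The change brings compound 3 close to compound 1 in the group on the amide-type nitrogen while it keeps the phenyl ether of compound 2. Among the measured compounds shown here, no measured step of this kind exists, so the size is a guess: a return toward a measurable number is expected, which in this assay means a lower number than compound 2 would need, though a fair chance remains that only a limit is reported. For compound 3 in this assay the estimate is 1500 nM, within 300 nM to 8000 nM.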

Compound 3, half-maximal effective concentration: 489 nM
Beside the measured number, compound 3's estimate is 3.1-fold (0.49 log units) above it; low and high end bracket the measured number.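

Among the compounds shown here, compound 2 stands without a number in this assay, and no step from it to compound 3 can be read. Open, going by these compounds, is how 1-(thiophen-2-yl)ethyl and (furan-2-yl)methyl on the amide-type nitrogen compare in size of effect. No supporting evidence bears on this result.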